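Tolerated concentration in the shared core: toward compound 4

A few compounds are considered here, and "the series" means these few. Any claim that something is new, unique, unknown or untested is made for them only; others in the source may bear on it.

Measured so far in an ADME assay on MT2 cells (Homo sapiens) for cytotoxicity, read by XTT assay, with a stated time of 4 days; a lower number here means that less compound is tolerated, a higher number that more compound is tolerated:
compound 1, `Cc1nc(C(NC(=O)C(=O)Nc2ccc(F)c(F)c2)C2CCCCN2)sc1CO`, gives a limit of > 87000 nM.
compound 2, `CC(=O)N1CCCCC1C(NC(=O)C(=O)Nc1ccc(Cl)cc1)c1nc(C)c(CCO)s1`, gives a limit of > 84000 nM.
compound 3, `Cc1nc(C(NC(=O)C(=O)Nc2ccc(F)c(Cl)c2)C2CCCCN2)sc1CCO`, gives 94700 nM.

Compound 2 stands at a limit, not a number: the limit of > 84000 nM in this assay, at which 1 of the 3 values shown sits. Compound 1 likewise sits at a limit, (the limit of > 87000 nM in this assay, at which 1 of the 3 values shown sits). Among the compounds with values here, compound 3 is the only one with a number, and that number lies close to both limits, so on the values shown the three compounds cannot be ranked in this assay. Within the data shown here, no pair among them differs in a single place, so no measured step is available.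

Compound 4, `Cc1nc(C(NC(=O)C(=O)Nc2ccc(Cl)cc2)C2CCCN2)sc1CCO`, differs from compound 2 in one place: pyrrolidin-2-yl in place of 1-acetylpiperidin-2-yl on a saturated chain carbon bound to an amide-type nitrogen and an aromatic carbon.

Given that every value shown sits at or near the upper reach of this assay, the step is expected to be none beyond the scatter, a step that the limit leaves unreadable from compound 2 to compound 4. Compound 4 is therefore estimated at 90000 nM, with a range from 40000 nM to 200000 nM, and a fair chance that only a limit is reported.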

Compound 4, half-maximal cytotoxic concentration: 42000 nM
Compound 4: the middle estimate sits 2.1-fold (0.33 log units) above what was measured; the measured number falls inside the stated range.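

In this assay, pyrrolidin-2-yl in place of 1-acetylpiperidin-2-yl on a saturated chain carbon bound to an amide-type nitrogen and an aromatic carbon gives an at least 2.0-fold lower number from compound 2 to compound 4 (0.30 log units; that floor lies within the scatter). Within the data shown here, this is the first measured step, and compound 4 gives it a number at one end, 42000 nM. The step can be read only as a floor, and its true size stays unknown because compound 2 stands at a limit: the limit of > 84000 nM in this assay, at which 1 of the 4 values shown sits.

The change alters the ring size and removes the acetyl group together, so the compounds shown do not say which part carries the step, or whether it exceeds the scatter. A 1-acetylpyrrolidin-2-yl group at this place would separate the two parts, and an azetidin-2-yl group would extend the ring-size comparison.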